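A few compounds are considered here, and "the series" means these few. Any claim that something is new, unique, unknown or untested is made for them only; others in the source may bear on it.

Measured so far:
compound 1 `O=C1/C(=C/c2ccccc2F)CN(C(=S)SCc2cn(Cc3ccccc3Cl)nn2)C/C1=C\c1ccccc1F`: 78700 nM
compound 2 `O=C1/C(=C/c2ccccc2F)CN(C(=S)SCc2cn(Cc3ccc(F)cc3)nn2)C/C1=C\c1ccccc1F`: 56900 nM
compound 3 `O=C1/C(=C/c2ccccc2F)CN(Cc2cn(Cc3ccccc3Cl)nn2)C/C1=C\c1ccccc1F`: 10000 nM

In a functional assay on MCF7 cells (Homo sapiens) for cytotoxicity, read by MTT assay, with a stated time of 24 h (on this read-out lower numbers stand for stronger inhibition and higher numbers for weaker inhibition), compound 1 gives 78700 nM. Compound 2 differs from compound 1 by 4-fluorophenyl in place of 2-chlorophenyl on a saturated chain carbon bound to an aromatic nitrogen, and the step is a 1.4-fold lower number from compound 1 to compound 2 (0.14 log units; within the scatter). Compound 3 has a different core from compound 1; the difference between the two cores is not broken down here. In this assay compound 3 gives 10000 nM, the lowest of the three numbers, with both steps to the other measured compounds beyond the scatter.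

Compound 4 `O=C1/C(=C/c2ccccc2F)CN(Cc2cn(Cc3ccc(F)cc3)nn2)C/C1=C\c1ccccc1F` is not yet measured. It differs from compound 3 by 4-fluorophenyl in place of 2-chlorophenyl on a saturated chain carbon bound to an aromatic nitrogen. The place is described in the same words as for the pair of compound 1 and compound 2, so this is the same change on a different core, and it is the second time the change occurs in the set.

The expected step is a 1.3-fold lower number from compound 3 to compound 4 (0.10 log units; within the scatter), estimated as small because the same change gave a 1.4-fold lower number from compound 1 to compound 2 (0.14 log units; within the scatter). For compound 4 the expected value in this assay is 8000 nM, estimated to lie between 3000 nM and 25000 nM.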

Compound 4, half-maximal inhibitory concentration: 6000 nM
Estimate against measurement, compound 4: 1.3-fold (0.12 log units) above; the range from low to high includes it.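

In this assay, the change from 2-chlorobenzyl to 4-fluorobenzyl gives a 1.7-fold lower number from compound 3 to compound 4 (0.22 log units; within the scatter), so the step on this core is small, as it is on the core of compound 1. The change therefore carries across these two cores with no difference that can be told from the scatter: the same change on two cores in this assay, a 1.4-fold lower number (0.14 log units; within the scatter) from compound 1 to compound 2 and a 1.7-fold lower number (0.22 log units; within the scatter) from compound 3 to compound 4, 1.2-fold (0.08 log units) apart, within the scatter of two such steps

This does not show that the change itself does anything in this assay, since neither step lies beyond the scatter, and two cores give no rule for a third core or for another change at this place.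

Within the data shown here, the only groups compared at this place are 2-chlorobenzyl and 4-fluorobenzyl, so it remains open how an unsubstituted benzyl, a 4-methoxybenzyl or a longer chain such as phenethyl would read on either core. On these data alone, it is also open whether an amine or a carboxylic acid on that benzyl ring would give a step beyond the scatter, and whether such a step would carry from one core to the other.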